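A few compounds are considered here, and "the series" means these few. Any claim that something is new, unique, unknown or untested is made for them only; others in the source may bear on it.

Series notes. The shared core is a fused two-ring system carrying a phenyl group and an aminomethyl side chain; compound 1 `CNCC1NCC(c2ccccc2)c2ccccc21` bears the secondary amine on that side chain, compound 2 `CN(C)CC1NCC(c2ccccc2)c2ccccc21` the (dimethylamino)methyl group. In an assay on cell membranes for binding affinity to muscarinic acetylcholine receptor M5 (Rattus norvegicus) (on this read-out lower numbers stand for stronger inhibition and higher numbers for weaker inhibition), compound 1 gives 2600 nM; 6300 nM (2 entries), and these repeated entries the several entries of compound 1 in this assay, 2600 nM; 6300 nM (2 entries) show how far duplicate measurements of one compound can lie apart here. In this assay, for the measured compounds named here, compound 2 gives 4000 nM, the only number it has; a further entry for compound 2 reports no single number. The values of compound 1 and compound 2 lie within the scatter of each other, so no order between the two can be drawn.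

Compound 3 `CN(C)CC1c2ccccc2C(c2ccccc2)CN1C` has not been measured. Relative to compound 2 the change is methyl in place of hydrogen on an amine nitrogen in a ring. Going by the values given here, no measured pair shows such a step, so its size and direction are unknown from these data. For this assay the step from compound 2 to compound 3 is expected to be a 1.3-fold higher number from compound 2 to compound 3 (0.10 log units; within the scatter), that is no change beyond the scatter. Compound 3 is estimated at 5000 nM, with a range of 1500 nM to 16000 nM.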

Compound 3, half-maximal inhibitory concentration: 1200 nM
For compound 3 the middle estimate is 4.2-fold (0.62 log units) above the measured one, and the stated range ends above it.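

In this assay, for the compounds shown here, methyl in place of hydrogen on an amine nitrogen in a ring gives a 3.3-fold lower number from compound 2 to compound 3 (0.52 log units; beyond the scatter), the first step that can be read. This places a measurable effect at the ring nitrogen next to the ring atom that bears a (dimethylamino)methyl group, and its direction is towards stronger inhibition, so a methyl group at this position is compatible with binding in this assay. The step is modest and rests on a single number each for compound 2 and compound 3, while the repeated entries available for judging how closely measurements agree come from a different compound: the several entries of compound 1 in this assay, 2600 nM; 6300 nM (2 entries)

From the compounds shown here alone, whether the trend continues with an ethyl group, a longer chain or an acetyl group on the ring nitrogen remains open, as one methyl step gives no trend in size. Going by these compounds, it is also open whether the same methyl step would act alike with the secondary amine side chain of compound 1, or with a substituted phenyl group in place of the phenyl group.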